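The compounds below may be only part of what the source reports. "The series", "measured", "known", "first", "only" and "open" are said of these compounds alone.

Working notes on the series in a functional assay on U-251 cells (Homo sapiens) for antiproliferative activity, read by MTT assay, with a stated time of 48 h; a lower number here means a stronger inhibitor, a higher number a weaker inhibitor. Compound 1 `COc1cc(-c2cccc3nc(-c4ccccc4)oc23)cc(OC)c1OC` gives 3500 nM, compound 2 `COc1ccc(-c2nc3cccc(-c4cc(OC)c(OC)c(OC)c4)c3o2)cc1F` gives 1700 nM, and compound 3 `COc1cc(-c2cccc3nc(-c4cccc(O)c4)oc23)cc(OC)c1OC` gives 5500 nM. Compound 3 cannot be separated from compound 1, with a 1.6-fold higher number from compound 1 to compound 3 (0.20 log units; within the scatter), but it stands clear of compound 2, with a 3.2-fold higher number from compound 2 to compound 3 (0.51 log units; beyond the scatter). It therefore sits at the high end of these numbers, level with compound 1.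

Compound 4 `COc1cc(-c2cccc3nc(-c4ccc5cc[nH]c5c4)oc23)cc(OC)c1OC` is the next entry, with this change: 1H-indol-6-yl in place of 3-hydroxyphenyl on an aromatic carbon. Going by the values given here, no 1H-indol-6-yl compound has been measured, so only the other changes at this aromatic carbon can guide the expectation. Among the compounds with values here, these are modest: a 2.1-fold lower number from compound 1 to compound 2 (0.31 log units; beyond the scatter) is the only other step beyond the scatter. Replacing the 3-hydroxyphenyl has so far given a lower number, as the step to compound 2 shows, so a modest move in that direction is expected, with wide uncertainty. The expected step is a 2.5-fold lower number from compound 3 to compound 4 (0.40 log units; beyond the scatter). For compound 4 the estimated value is 2200 nM, with an expected range from 600 nM to 6500 nM.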

Compound 4, half-maximal inhibitory concentration: 300 nM
Compound 4: the middle estimate sits 7.3-fold (0.87 log units) above what was measured; the measured number lies below the stated range.
By their numbers in this assay, from the lowest: compound 4; then compound 2; then compounds 1 and 3 (each within the scatter of the next).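

At this aromatic carbon, next to the ring nitrogen and next to the ring oxygen, a ring system with a five-membered aromatic ring on a six-membered one gives far more than the earlier phenyl changes did in this assay (an 18-fold lower number from compound 3 to compound 4 (1.26 log units; beyond the scatter)) and (a 12-fold lower number from compound 1 to compound 4 (1.07 log units; beyond the scatter)). The 1H-indol-6-yl group also stands clear of the 3-fluoro-4-methoxyphenyl group (a 5.7-fold lower number from compound 2 to compound 4 (0.75 log units; beyond the scatter)), so this position can reach much lower numbers than the single-ring groups suggested. Nothing at hand explains the gain.

Going by these compounds alone, with only one fused group, the contribution of the indole hydrogen on nitrogen cannot be separated from that of the second ring. A naphthyl group, with carbon only, would separate the two, and an N-methylindolyl group would test the indole hydrogen directly.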